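Acylsulfonamide series: sulfonyl substituent and microsomal stability

The source may hold more compounds than are shown below. What is called first, only, known or untested is meant among the compounds shown, and "the series" means these compounds.

Three acylsulfonamides sharing one core have been run in an ADME assay on microsomes from liver (Homo sapiens) for metabolic stability, with a stated time of 10 min; a higher number here means that more of the compound is left, a lower number that less of the compound is left. Compound 1 `O=C(NS(=O)(=O)c1ccc(F)cc1)c1ccc(Nc2nc(NC3(c4ccc(Cl)cc4)CC3)nc(OCC(F)(F)F)n2)cc1` gives 100%. Compound 2 `CC(C)(C)OC(=O)NCCS(=O)(=O)NC(=O)c1ccc(Nc2nc(NC3(c4ccc(Cl)cc4)CC3)nc(OCC(F)(F)F)n2)cc1` gives 92%. Compound 3 `CC(C)NC(=O)NCCS(=O)(=O)NC(=O)c1ccc(Nc2nc(NC3(c4ccc(Cl)cc4)CC3)nc(OCC(F)(F)F)n2)cc1` gives 100%. Compound 3 thus sits level with compound 1 at the digits shown, the two together forming the top of the set, with compound 2 the furthest away; the step of a number 8 percentage points higher from compound 2 to compound 3 (within the scatter) is within the scatter, as are no change at the digits printed from compound 1 to compound 3 (within the scatter) and a number 8 percentage points lower from compound 1 to compound 2 (within the scatter). Across these three, exchanging the group on the sulfonyl sulfur has left the read-out unchanged within the scatter.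

Compound 4 `CS(=O)(=O)NC(=O)c1ccc(Nc2nc(NC3(c4ccc(Cl)cc4)CC3)nc(OCC(F)(F)F)n2)cc1` is the next entry. Its change from compound 3 is hydrogen in place of ((isopropylcarbamoyl)amino)methyl on a saturated chain carbon bound to a sulfonyl sulfur, leaving a methylsulfonyl in place of the (2-((isopropylcarbamoyl)amino)ethyl)sulfonyl.

Within the data shown here, no measured step removes the whole chain and leaves a methyl in its place. The bearing of the three steps is therefore indirect: each shows that this position tolerates quite different substituents without a change beyond the scatter. On that basis the step of a number 4 percentage points lower from compound 3 to compound 4 (within the scatter) is expected to stay within the scatter. Compound 4 is therefore estimated at 96% in this assay, with a range from 84% to 100%.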

Compound 4, percent of the compound remaining: 100%
Compound 4: the middle estimate sits 4 percentage points below what was measured; low and high end bracket the measured number.
By their numbers in this assay, from the lowest: compounds 2, 1, 3 and 4 (each within the scatter of the next).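

In this assay the direct removal of ((isopropylcarbamoyl)amino)methyl from the saturated chain carbon bound to a sulfonyl sulfur gives no change at the digits printed from compound 3 to compound 4 (within the scatter) and the matching removal of ((tert-butoxycarbonyl)amino)methyl gives a number 8 percentage points higher from compound 2 to compound 4 (within the scatter) in the same read-out, so this position has now been seen with the whole chain gone and not only with one chain exchanged for another. Methyl in place of 4-fluorophenyl on the sulfonyl sulfur gives no change at the digits printed from compound 1 to compound 4 (within the scatter) and extends the finding to a plain alkyl group with no ring, and none of the four compounds goes against the pattern that the sulfonyl substituent leaves this read-out unchanged within the scatter. Nothing shown here bears on why the read-out holds across these groups.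

The compounds shown leave open how a free amine or a carboxylic acid at the end of the ethyl chain, or a longer chain on the sulfonyl sulfur, would read in this assay at this stated time. Among these compounds, they also leave open whether any exchange at this position separates from compound 4 at 100% by more than the scatter, since all steps so far stay within it.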